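This account rests on a few compounds, and the source may have more. Where it says the series, first, only, none or still open, it means among the compounds named here.

Compound 1 `O=C(CCCCCc1ccccc1)OCC1COCCOCCOCCOCCOCCO1`: 79000 nM
Compound 2 `O=C(CCCCOc1ccccc1)OCC1COCCOCCOCCOCCOCCO1`: > 100000 nM (a limit)

Among the measured compounds shown here, in a functional assay on HeLa cells (Homo sapiens) for inhibition, read by sulforhodamine B assay, with a stated time of 48 h (a higher number here means a weaker inhibitor of growth, a lower number a stronger inhibitor of growth), compound 1 gives 79000 nM, the only actual number available. Compound 2 stands at the limit of > 100000 nM in this assay, at which 1 of the 2 values shown sits. Compound 3 `CC(=O)OCC1COCCOCCOCCOCCOCCO1` has not yet been measured, and its change from compound 1 is hydrogen in place of 4-phenylbutyl on a saturated chain carbon bound to a carbonyl carbon. Read one bond further out, this is 5-phenylpentyl to methyl.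

For the measured compounds named here, only one measured step bears on this: an at least 1.2-fold higher number from compound 1 to compound 2 (0.10 log units; that floor lies within the scatter). That step alters the chain rather than removing it, ends in a limit, and stays within the scatter, so it offers only weak guidance. In this assay, going by the values given here, no step clearly beyond the scatter is therefore expected, only a possible drift toward a higher number. The expected size is a 1.6-fold higher number from compound 1 to compound 3 (0.22 log units; within the scatter). Compound 3 is estimated at 130000 nM, with an expected range of 60000 nM to 300000 nM.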

Compound 3, concentration for 50% growth inhibition: > 100000 nM
Compound 3: only a limit was reported; the forecaster's own chance of this, stated with the estimate: 75%; the middle value lies beyond the limit too.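

Taking the chain away altogether, with hydrogen in place of 4-phenylbutyl on a saturated chain carbon bound to a carbonyl carbon, gives an at least 1.2-fold higher number from compound 1 to compound 3 (0.10 log units; that floor lies within the scatter). In this assay compound 3 reads > 100000 nM, which is a limit. Unlike the earlier step, which only altered the chain, this one shows that the core with a bare acetate ester gives no measured number either, although its floor stays within the scatter, and the step between compound 2 and compound 3 cannot be read: the limit of > 100000 nM in this assay, at which 2 of the 3 values shown sit.

The compounds shown therefore leave open whether the 4-phenylbutyl group contributes to growth inhibition at all. They also leave open how a longer chain, or an amine or a carboxylic acid at the chain end, would read in this assay.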